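The source may report more compounds than this note shows. Statements on the series, on what has been measured and on what is new or still open speak of the compounds shown alone.

Compound 2 `CCc1nc2ccccc2c(=O)n1NC(=O)Nc1ccc(OC)cc1` is one of two compounds tested in a functional assay on the whole organism (strain albino) with Mus musculus as the target, at a dose of 100 mg/kg by the intraperitoneal route (a lower number here means less inhibition, a higher number more inhibition at the dose given (going by the name of the read-out)), so far. In this assay compound 2 gives 48%, the lower of the two numbers, while compound 1 `CCc1nc2ccccc2c(=O)n1NC(=O)Nc1ccc(C)cc1` gives 55%. Among the measured compounds shown here, the only step between them is the replacement of methyl by methoxy on an aromatic carbon, which moves the read-out by a number 7 percentage points lower from compound 1 to compound 2 (within the scatter).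

Compound 3 `CCc1nc2ccccc2c(=O)n1NC(=O)Nc1ccc(F)cc1` has not been measured. It differs from compound 2 in one place: fluoro in place of methoxy on an aromatic carbon. The exchange sits on an aromatic carbon of a six-membered aromatic ring of carbon only, para to a large group, the same spot where compound 1 and compound 2 differ.

For the measured compounds named here, only the step from compound 1 to compound 2 bears on this change, and it stayed within the scatter. A similar swap of the group at this position is therefore expected to move the read-out little, giving an expected step of a number 2 percentage points higher from compound 2 to compound 3 (within the scatter). For compound 3 the expected value in this assay is 50%, with a range from 35% to 65%.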

Compound 3, a percentage reported as inhibition, in the whole organism at one dose (the size of the read-out at that dose, not a potency): 51%
Beside the measured number, compound 3's estimate is 1 percentage points below it; low and high end bracket the measured number.
By their numbers in this assay, from the lowest: compounds 2, 3 and 1 (each within the scatter of the next).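

Fluoro now joins methyl and methoxy on this aromatic carbon, and in this assay the swap from methoxy gives a number 3 percentage points higher from compound 2 to compound 3 (within the scatter) while the swap from methyl gives a number 4 percentage points lower from compound 1 to compound 3 (within the scatter). Every pair among these three compounds therefore lies within the scatter, so the single earlier step now has company: replacing one of these small groups with another at this spot produces no readable change in this assay. No available evidence accounts for this similarity.

As far as these compounds go, it remains open whether a different kind of group at this spot, such as an amine, a carboxylic acid or a longer chain, would move the read-out beyond the scatter. The results also leave open how changes elsewhere on the shared core would behave, and because each compound was read at one dose, they do not give potency.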